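Swapping chloro for methyl on a compound at the limit

A few compounds are considered here, and "the series" means these few. Any claim that something is new, unique, unknown or untested is made for them only; others in the source may bear on it.

Measured so far in a functional assay on CCRF-CEM cells (Homo sapiens) for antiproliferative activity, read by cell counting, with a stated time of 2 days (on this read-out higher numbers stand for weaker inhibition and lower numbers for stronger inhibition), as follows
Compound 1 `COc1ccc(C(=O)c2sc(Nc3ccc(Cl)cc3)nc2N)cc1` gives > 10000 nM as a limit
Compound 2 `Nc1nc(Nc2ccc(Cl)cc2)sc1C(=O)c1ccccc1` gives > 10000 nM as a limit
Compound 3 `COc1cc(C(=O)c2sc(Nc3ccc(C)cc3)nc2N)cc(OC)c1OC` gives 41 nM as a number

The entry for compound 2 is a limit and not a number. Compound 2 thus stands at the limit of > 10000 nM in this assay, at which 2 of the 3 values shown sit, and has no exact position on the scale. The entry for compound 1 is a limit too. Among the compounds with values here, compound 3 alone has a true number, 41 nM in this assay for compound 3, but no single-place step connects it to the others.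

Compound 4 `Cc1ccc(Nc2nc(N)c(C(=O)c3ccccc3)s2)cc1` differs from compound 2 in one place, with methyl in place of chloro on an aromatic carbon, para to a large group methyl in place of chloro on an aromatic carbon and nothing else changed.

Within the data shown here, only one single-place step has been measured, a step that the two limits leave unreadable from compound 1 to compound 2 and it is a different change, hydrogen in place of methoxy. Among the measured compounds shown here, its size cannot be read, so no measured step gives a size for this swap. The expectation in this assay therefore rests on compound 2 and its > 10000 nM limit, with no step beyond the scatter in either direction. The expected result is a number no higher from compound 2 to compound 4 (the limit leaves the size open) in this estimate. For compound 4 the estimated value is 10000 nM (expected range 3000 nM to 30000 nM) and a limit rather than a number is the likeliest report.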

Compound 4, half-maximal inhibitory concentration: 370 nM
Estimate against measurement, compound 4: 27-fold (1.43 log units) above; the measured number lies below the stated range.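

In this assay, within the data shown here, the swap of 4-chlorophenyl to 4-methylphenyl gives an at least 27-fold lower number from compound 2 to compound 4 (1.43 log units; beyond the scatter), the first step in this set with a readable size, as the earlier step from compound 1 to compound 2 cannot be read. This shows that the aromatic carbon para to a large group is a sensitive position: exchanging one heavy atom for another, with no change in the count of hydrogen-bond donors or acceptors, is enough to turn a limit into a true number. Compound 4 gives 370 nM. The step sets only a minimum size, because the entry for compound 2 is a limit and not a number: the limit of > 10000 nM in this assay, at which 2 of the 4 values shown sit.

What in the swap produces this gain cannot be told from one pair of compounds, and neither can whether methyl in place of chloro would act in the same way on compound 1, whose entry is also a limit. Going by these compounds, it also remains open how an ethyl, a bromo or an amine on this same carbon would compare with the methyl of compound 4.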